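A few compounds are considered here, and "the series" means these few. Any claim that something is new, unique, unknown or untested is made for them only; others in the source may bear on it.

Compound 3 `CC1CCN(c2c(S(=O)(=O)c3ccc(Cl)cc3)cnc3c(F)cccc23)CC1` gives 85% in an assay on isolated protein for displacement of a labelled ligand from metabotropic glutamate receptor 5 (Homo sapiens), with a stated time of 60 min, tested at 1 uM; on this read-out higher numbers stand for more inhibition at the one concentration tested (going by the name of the read-out) and lower numbers for less inhibition. Its nearest neighbour is compound 2 `COCC1CCN(c2c(S(=O)(=O)c3cc(F)cc(F)c3)cnc3cc(F)ccc23)CC1`, which gives 83% in this assay, and the remaining number comes from compound 1 `Cc1ccc(S(=O)(=O)c2cnc3c(F)cccc3c2N2CCC(C)CC2)cc1`, which gives 93%; all three numbers lie within the usual scatter of one another, so no order among them is claimed. Going by the values given here, the one step that changes a single place, a number 8 percentage points lower from compound 1 to compound 3 (within the scatter), replaces one group on the same aromatic ring that is altered again in compound 4 `CC1CCN(c2c(S(=O)(=O)c3ccc(F)c(F)c3)cnc3c(F)cccc23)CC1`, where the change is 3,4-difluorophenyl in place of 4-chlorophenyl on a sulfonyl sulfur. That step bears on the present one, and it lay within the scatter, so no shift beyond the scatter is expected: the step of a number 1 percentage points lower from compound 3 to compound 4 (within the scatter) is an estimate. Compound 4 is therefore expected to give about 84%, plausibly between 70% and 95%.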

Compound 4, a percentage reported as inhibition, at one concentration (the size of the read-out at that concentration, not a potency): 93%
Estimate against measurement, compound 4: 9 percentage points below, and the stated range covers the measured number.
By their numbers in this assay, from the lowest: compounds 2, 3, 1 and 4 (each within the scatter of the next).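

Three aryl groups on a sulfonyl sulfur can now be compared on the same core in this assay: the 3,4-difluorophenyl group gives a number 8 percentage points higher from compound 3 to compound 4 (within the scatter) and no change at the digits printed from compound 1 to compound 4 (within the scatter). Exchanging 4-chlorophenyl or 4-methylphenyl for 3,4-difluorophenyl at this place therefore produces no shift that can be told from the scatter. Nothing available explains why these groups read alike. Open, as far as these compounds go, is how this place responds to a group other than a substituted phenyl, such as a pyridine ring or a cyclohexyl ring. Readings at one concentration also leave the potencies of these compounds unresolved.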